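This account rests on a few compounds, and the source may have more. Where it says the series, first, only, none or still open, it means among the compounds named here.

Compound 3 `Cn1cc(SCc2nnc(SCc3cc(C(F)(F)F)ccc3Cl)n2-c2c(Cl)cccc2Cl)c2ccccc21` gives 53800 nM in a toxicity assay on HEK-293T cells (Homo sapiens) for cytotoxicity, read by CCK-8 assay, with a stated time of 48 h (a lower number here means that less compound is tolerated, a higher number that more compound is tolerated), the lowest of the two numbers shown; the nearest is compound 2 `Cn1cc(SCc2nnc(SCc3ccccc3C#N)n2-c2c(Cl)cccc2Cl)c2ccccc21`, which gives 78600 nM in this assay. Compound 1 `Cn1cc(SCc2nnc(SCc3ccccc3)n2-c2c(Cl)cccc2Cl)c2ccccc21` gives only a limit of this assay, > 100000 nM. Compound 4 `Cn1cc(SCc2nnc(SCc3ccc(Cl)cc3Cl)n2-c2c(Cl)cccc2Cl)c2ccccc21` has not been measured; it differs from compound 3 in one place: 2,4-dichlorophenyl in place of 2-chloro-5-(trifluoromethyl)phenyl on a saturated chain carbon bound to a sulfur.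

Three measured steps change the same part of the shared core. The step of an at least 1.8-fold lower number from compound 1 to compound 3 (0.26 log units; that floor lies within the scatter) and the step of a 1.5-fold lower number from compound 2 to compound 3 (0.16 log units; within the scatter) both swap the group on the saturated chain carbon bound to a sulfur, and the step of an at least 1.2-fold lower number from compound 1 to compound 2 (0.10 log units; that floor lies within the scatter) changes a substituent on that same group. Each of these steps stays within the scatter. A swap of one substituted phenyl for another at this place is therefore expected to give no step beyond the scatter, in either direction, in this assay. Compound 4 is accordingly estimated at 55000 nM, within a range of 25000 nM to 100000 nM, which is expected to be a step of a 1.0-fold higher number from compound 3 to compound 4 (0.01 log units; within the scatter).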

Compound 4, half-maximal cytotoxic concentration: > 100000 nM
Compound 4 gave a limit, no number (the forecaster's own chance of this, stated with the estimate: 25%); middle value at least 1.8-fold (0.25 log units) from the limit.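

Placing 2,4-dichlorophenyl on the saturated chain carbon bound to a sulfur gives an at least 1.8-fold higher number from compound 3 to compound 4 (0.26 log units; that floor lies within the scatter), and measured against the 2-cyanophenyl group it gives an at least 1.2-fold higher number from compound 2 to compound 4 (0.10 log units; that floor lies within the scatter). Both are only floors, so neither establishes a real difference, although the true steps could be larger. Chlorine on this phenyl therefore does not by itself bring the number down in this assay, since compound 4, with two chlorines, gives a limit and not a number, the same limit as compound 1 with its plain phenyl: the limit of > 100000 nM in this assay, at which 2 of the 4 values shown sit.

The step between those two limits cannot be read. As far as these compounds go, whether an amine or a carboxylic acid on this phenyl, or a longer chain in place of the benzyl group, would bring the number down remains open.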